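Methoxyphenyl amides on a shared core: gastric cell growth

This account rests on a few compounds, and the source may have more. Where it says the series, first, only, none or still open, it means among the compounds named here.

Measured compounds:
compound 1, `COc1ccc(NC(=O)C2c3ccccc3CCN2C(=O)c2ccc(Cl)cc2)cc1`, 3630 nM
compound 2, `COc1ccccc1NC(=O)C1NCCc2ccccc21`, > 10000 nM
compound 3, `O=C(Nc1cccc(O)c1)C1c2ccccc2CCN1C(=O)c1ccc(Cl)cc1`, > 10000 nM

The read-out throughout is a functional assay on NUGC-3 cells (Homo sapiens) for inhibition, read by sulforhodamine B assay, with a stated time of 48 h; on this read-out higher numbers stand for weaker inhibition of growth and lower numbers for stronger inhibition of growth. Compound 3 stands at the limit of the assay, reported as > 10000 nM, which is a limit and not a number. Compound 2 likewise sits at a limit, > 10000 nM. Only compound 1 gives a number, 3630 nM. Compound 3 is thus among the weaker entries shown, and its exact position is unknown because the limit of > 10000 nM in this assay, at which 2 of the 3 values shown sit, holds it at that limit.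

Compound 4, `COc1ccccc1NC(=O)C1c2ccccc2CCN1C(=O)c1ccc(Cl)cc1`, differs from compound 3 in one place: 2-methoxyphenyl in place of 3-hydroxyphenyl on an amide-type nitrogen. Among the compounds with values here, the one measured step that bears on this site is an at least 2.7-fold higher number from compound 1 to compound 3 (0.44 log units; beyond the scatter), which shows that exchanging the group on the amide-type nitrogen can shift the result beyond the scatter. Within the data shown here, no measured step compares 2-methoxyphenyl with 3-hydroxyphenyl on this core; compound 2 carries the 2-methoxyphenyl but lacks the chlorobenzoyl group, so its limit value cannot be read as a step.

Compound 4 is therefore estimated at 8000 nM, within 2500 nM to 25000 nM. The expected step of an at least 1.2-fold lower number from compound 3 to compound 4 (0.09 log units; that floor lies within the scatter) is small and uncertain, since compound 3 itself is known only as a limit.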

Compound 4, concentration for 50% growth inhibition: 1590 nM
The estimate for compound 4 lay 5.0-fold (0.70 log units) above the measured number; the whole stated range lies above it.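

In this assay, 2-methoxyphenyl in place of 3-hydroxyphenyl on the amide-type nitrogen gives an at least 6.2-fold lower number from compound 3 to compound 4 (0.79 log units; beyond the scatter), so a change at this position can lower the number, whereas the earlier step of an at least 2.7-fold higher number from compound 1 to compound 3 (0.44 log units; beyond the scatter) had shown only a rise. Between the two methoxyphenyl groups on this nitrogen there is a 2.3-fold lower number from compound 1 to compound 4 (0.36 log units; beyond the scatter), so on the shared core 2-methoxyphenyl and 4-methoxyphenyl are separated by more than the scatter, and the lower number belongs to 2-methoxyphenyl. With 2-methoxyphenyl held fixed, (4-chlorophenyl)carbonyl in place of hydrogen on the amine nitrogen in a ring gives an at least 6.2-fold lower number from compound 2 to compound 4 (0.79 log units; beyond the scatter), which shows that this second site also shifts the result.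

Going by these compounds, the full size of the steps from compound 2 and compound 3 stays open, since each of those two compounds is held at a limit and these steps are floors only: the limit of > 10000 nM in this assay, at which 2 of the 4 values shown sit. Also open, on these data alone, is how an ethoxy group, an amine or a carboxylic acid would compare with the methoxy group on this phenyl ring.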